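The compounds below may be only part of what the source reports. "The series", "measured", "known", "first", "only" and "open" are said of these compounds alone.

Three compounds built on one shared core have been run in a functional assay on FM3A cells (Mus musculus) for inhibition, read by cell counting, with a stated time of 2 days; a lower number here means a stronger inhibitor, a higher number a weaker inhibitor. Compound 1 `Nc1cccc(-c2cn3nc(-c4cccs4)sc3n2)c1` carries a free amine on its phenyl ring; in this assay compound 1 gives > 250000 nM, which is a limit of the assay rather than a number. Compound 3 `CCOc1ccc(-c2nn3cc(-c4cccc(N)c4)nc3s2)cc1` carries the same free amine; in this assay compound 3 gives >= 250000 nM, again a limit and not a number. Compound 2 `C=C(Br)C(=O)Nc1cccc(-c2cn3nc(-c4ccc(F)cc4)sc3n2)c1` instead has that nitrogen capped as an amide, and in this assay compound 2 gives 610 nM. For the measured compounds named here, this is the only true number among the three values shown; the other two sit at a limit.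

Compound 4 `C=C(Br)C(=O)Nc1cccc(-c2cn3nc(-c4ccc(OC)c(OC)c4)sc3n2)c1` keeps the amide of compound 2 and alters only the aryl group on the other side of the core: 3,4-dimethoxyphenyl in place of 4-fluorophenyl on an aromatic carbon. Going by the values given here, no measured pair differs in exactly this one place, so the size of this step cannot be read from the data. Compound 1 and compound 3, the two compounds without the amide, each sit at a limit of the assay. Compound 2, which has the amide, gives 610 nM in this assay; the amide thus appears to carry the activity here, and the aryl change is expected to matter less. The step from compound 2 to compound 4 is expected to be a 2.0-fold higher number from compound 2 to compound 4 (0.29 log units; within the scatter), a slight loss that may not exceed the scatter. In this assay compound 4 is therefore expected to give about 1200 nM, with a range from 300 nM to 6000 nM.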

Compound 4, half-maximal inhibitory concentration: 110 nM
The estimate for compound 4 lay 11-fold (1.04 log units) above the measured number, and the stated range ends above it.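

With the amide held fixed, 3,4-dimethoxyphenyl in place of 4-fluorophenyl gives in this assay a 5.5-fold lower number from compound 2 to compound 4 (0.74 log units; beyond the scatter), so the aryl group at this position of the shared core can change the number by itself, beyond the usual scatter. For the compounds shown here, until this pair, no two measured compounds differed in one place alone, so the aryl group could not be judged apart from the amide. Nothing measured here bears on why the number falls with this change.

This single pair removes the fluorine and adds both methoxy groups in one step, so it leaves open whether one methoxy group alone would give the same change, and how a plain phenyl ring, or a phenyl ring carrying a carboxylic acid or a morpholine, would compare. It also leaves open whether 3,4-dimethoxyphenyl would lift a compound with the free amine away from the assay limit, or whether this aryl group counts only when the amide is present.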